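The source may hold more compounds than are shown below. What is called first, only, known or untested is meant among the compounds shown, and "the series" means these compounds.

Measured so far:
- compound 1, `CCOc1ccccc1N1CCN(CCCNc2ncccc2C(=O)N(C)C)CC1`: 0.501 nM in a functional assay for antagonist activity at Alpha-1A adrenergic receptor (Oryctolagus cuniculus); a higher number here means weaker binding, a lower number tighter binding
- compound 2, `CN(C)C(=O)c1cccnc1NCCCN1CCN(c2ccccc2-c2ccccc2)CC1`: 1.26 nM

Compound 2 holds the highest of the two numbers in this assay, with compound 1 the nearest at a 2.5-fold higher number from compound 1 to compound 2 (0.40 log units; beyond the scatter) reversed. Compound 3, `CSc1ccccc1N1CCN(CCCNc2ncccc2C(=O)N(C)C)CC1`, differs from compound 2 by methylsulfanyl in place of phenyl on an aromatic carbon. Among the compounds with values here, the one measured step that bears on this, a 2.5-fold higher number from compound 1 to compound 2 (0.40 log units; beyond the scatter), replaced a small group by phenyl and raised the number modestly; the change to compound 3 removes phenyl for a small group again, so a modest step back down is expected, a 2.1-fold lower number from compound 2 to compound 3 (0.32 log units; beyond the scatter). Compound 3 is therefore estimated at 0.6 nM, within 0.25 nM to 1.5 nM.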

Compound 3, dissociation constant: 0.631 nM
Compound 3: the middle estimate sits 1.1-fold (0.02 log units) below what was measured, and the stated range covers the measured number.
By their numbers in this assay, from the lowest: compounds 1, 3 and 2 (each within the scatter of the next, the first and the last beyond it).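

In this assay, methylsulfanyl on this aromatic carbon, ortho to a large group, cannot be told apart from either earlier group, with a 2.0-fold lower number from compound 2 to compound 3 (0.30 log units; within the scatter) against phenyl and a 1.3-fold higher number from compound 1 to compound 3 (0.10 log units; within the scatter) against ethoxy. Ethoxy and phenyl stand apart beyond the scatter, yet methylsulfanyl lies within it of both, so this change gives no order among the three compounds. Nothing available explains this result. The compounds shown leave open whether an amine, a carboxylic acid or a longer chain such as butoxy at this position would stay in the same range.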